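This account rests on a few compounds, and the source may have more. Where it says the series, first, only, none or still open, it means among the compounds named here.

Two members of this small series have been tested. Compound 1 `N#CC1CN1C(=O)Nc1ccc(F)cc1` and compound 2 `N#CC1CN1C(=O)Nc1ccc(Cl)cc1Cl` share a core built around a nitrile-bearing three-membered ring joined through a urea to a substituted benzene ring. In a functional assay on MCF7 cells (Homo sapiens) for inhibition (on this read-out lower numbers stand for stronger inhibition and higher numbers for weaker inhibition), compound 1 gives 2400 nM, the highest of the two numbers; in this assay compound 2 gives 1100 nM, a lower number that lies beyond the usual scatter. The two differ in more than one place, so their values alone say nothing about any single change.

The next compound, compound 3 `N#CC1CN1C(=O)Nc1ccc([N+](=O)[O-])cc1`, differs from compound 1 in one place: nitro in place of fluoro on an aromatic carbon. Among the compounds with values here, with only two measured compounds and no single-change comparison among them, there is no basis for expecting a step beyond the scatter in this assay, in either direction. For compound 3 the estimate is therefore 1800 nM, with a range from 600 nM to 5500 nM, which amounts to an expected step of a 1.3-fold lower number from compound 1 to compound 3 (0.12 log units; within the scatter).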

Compound 3, half-maximal inhibitory concentration: 3000 nM
Beside the measured number, compound 3's estimate is 1.7-fold (0.22 log units) below it; the measured number falls inside the stated range.
By their numbers in this assay, from the lowest: compound 2; then compounds 1 and 3 (each within the scatter of the next).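

In this assay, within the data shown here, the step of a 1.3-fold higher number from compound 1 to compound 3 (0.10 log units; within the scatter) for nitro in place of fluoro is the first comparison that isolates a single change. On the aromatic carbon para to a group of 8 heavy atoms, a group of 3 heavy atoms with 2 hydrogen-bond acceptors thus replaces a lone fluorine without a step that stands clear of repeat-measurement noise. Nothing measured here explains why these two groups read alike.

On these data alone, whether a different kind of group at this position, such as an amine, a carboxylic acid or a longer alkyl chain, would give a step beyond the scatter remains open. Compound 2 differs from compound 1 in more than one place, so a compound with only chloro in place of fluoro would be needed to begin separating its changes.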